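Swapping amino for hydroxy on a shared anilino core

This account rests on a few compounds, and the source may have more. Where it says the series, first, only, none or still open, it means among the compounds named here.

Compound 1 `Cc1nc(Nc2ccc(I)cc2)c2cc[nH]c2n1` and compound 2 `Cc1nc(Nc2ccc(N)cc2)c2cc[nH]c2n1` share one core and differ only in the group on the outer aromatic ring. In a functional assay on the whole organism for inhibition, with Nicotiana tabacum as the target (a higher number here means a weaker inhibitor, a lower number a stronger inhibitor), compound 1 gives 219000000 nM, and compound 2 gives 195000000 nM. Within the data shown here, the one measured step, a 1.1-fold lower number from compound 1 to compound 2 (0.05 log units; within the scatter), is therefore too small to be told from repeat measurements. Compound 2 stands at the lower of the two numbers, but with compound 1 so close this is no real ordering.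

Compound 3 `Cc1nc(Nc2ccc(O)cc2)c2cc[nH]c2n1` is the next variation: hydroxy in place of amino on an aromatic carbon. Among the measured compounds shown here, no measured step swaps these two particular groups, so the only guide is that the earlier exchange of iodo for amino at this same place left this assay essentially unchanged. The expected step is a 1.0-fold higher number from compound 2 to compound 3 (0.01 log units; within the scatter), that is, none beyond the scatter, an expectation resting on how little this assay moved from compound 1 to compound 2.

For compound 3 the estimated value in this assay is 200000000 nM, with a range from 100000000 nM to 400000000 nM.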

Compound 3, half-maximal inhibitory concentration: 155000000 nM
Compound 3: the middle estimate sits 1.3-fold (0.11 log units) above what was measured; low and high end bracket the measured number.
By their numbers in this assay, from the lowest: compounds 3, 2 and 1 (each within the scatter of the next).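

Putting hydroxy at this place gives a 1.3-fold lower number from compound 2 to compound 3 (0.10 log units; within the scatter) when it replaces amino, and a 1.4-fold lower number from compound 1 to compound 3 (0.15 log units; within the scatter) when it replaces iodo. Among these compounds, the earlier pair offered only one exchange, whereas three groups now occupy the same aromatic carbon, para to a large group, and all three pairs among them lie within the scatter in this assay. This result adds the exchange of a nitrogen-bearing group for an oxygen-bearing one with the same count of hydrogen-bond donors and acceptors, yet no available measurement bears on why these compounds cannot be told apart.

Going by these compounds, three groups are a small sample, so it remains open whether a carboxylic acid, a methoxy group or a longer chain such as butyl on this same aromatic carbon would give a number clearly separated from these. All three compounds also keep the rest of the shared core unchanged, so they say nothing about how this assay would respond if the methyl group on that core gave way to an ethyl group or a hydrogen atom.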